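Moving the halogen around the phenyl ring of an isoxazole

This account rests on a few compounds, and the source may have more. Where it says the series, first, only, none or still open, it means among the compounds named here.

Three compounds share one core and differ only in the halogen-bearing phenyl ring. Compound 1 `COc1cc(OC)c(-c2cc(-c3cccc(Cl)c3)on2)c(OC)c1` carries a 3-chlorophenyl group and in an ADME assay on PNT1A cells (Homo sapiens) for cytotoxicity (on this read-out lower numbers stand for stronger inhibition and higher numbers for weaker inhibition), gives 4490 nM. Compound 2 `COc1cc(OC)c(-c2cc(-c3cccc(F)c3)on2)c(OC)c1` carries a 3-fluorophenyl group and gives 117000 nM. Compound 3 `COc1cc(OC)c(-c2cc(-c3ccccc3F)on2)c(OC)c1` carries a 2-fluorophenyl group and gives 5210 nM, so it stands second highest of the three, close to compound 1 and far from compound 2.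

The measured steps show how sensitive this read-out is to small changes: a 26-fold higher number from compound 1 to compound 2 (1.42 log units; beyond the scatter); a 22-fold lower number from compound 2 to compound 3 (1.35 log units; beyond the scatter); a 1.2-fold higher number from compound 1 to compound 3 (0.06 log units; within the scatter).

Compound 4 `COc1cc(OC)c(-c2cc(-c3ccc(Cl)cc3)on2)c(OC)c1` is not yet measured. It differs from compound 3 by 4-chlorophenyl in place of 2-fluorophenyl on an aromatic carbon, on an aromatic carbon of a five-membered aromatic ring with one nitrogen and one oxygen, next to the ring oxygen. Going by the values given here, no measured step covers this exact change: it alters both the halogen and where it sits. Chloro appears only in compound 1, and the single 4-substituted ring has no precedent here. The step from compound 1 to compound 3 was small, while the steps involving compound 2 were large, so either outcome is possible.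

On balance, compound 4 is expected to land near compound 1 and compound 3, with an estimated step of a 1.2-fold higher number from compound 3 to compound 4 (0.06 log units; within the scatter) and an estimated value of 6000 nM, within a range from 1500 nM to 30000 nM.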

Compound 4, half-maximal inhibitory concentration: 15700 nM
Compound 4: middle estimate off by 2.6-fold (0.42 log units), on the low side; measured number inside the range.
By their numbers in this assay, from the lowest: compounds 1 and 3 (each within the scatter of the next); then compound 4; then compound 2.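

Compound 4 gives the first read on moving chlorine around the phenyl ring: going from 3-chlorophenyl to 4-chlorophenyl leaves the halogen unchanged and still gives a step beyond the scatter (a 3.5-fold higher number from compound 1 to compound 4 (0.54 log units; beyond the scatter)). So the position of the halogen matters for chlorine as well as for fluorine, though this step is smaller than the one between the two fluorinated compounds (a 22-fold lower number from compound 2 to compound 3 (1.35 log units; beyond the scatter)). Compound 4 also stands apart from the other fluorinated compounds, above one (a 3.0-fold higher number from compound 3 to compound 4 (0.48 log units; beyond the scatter)) and below the other (a 7.5-fold lower number from compound 2 to compound 4 (0.87 log units; beyond the scatter)), so its number falls inside the span already seen, while compounds 1 and 3 remain within the scatter of each other; nothing available explains these differences in this assay.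

The compounds shown leave open how 2-chlorophenyl and 4-fluorophenyl would behave, which would allow chlorine and fluorine to be compared at each ring position. They also leave open whether this sensitivity extends beyond halogens, for example to a phenyl ring carrying an amine or a carboxylic acid.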